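A few compounds are considered here, and "the series" means these few. Any claim that something is new, unique, unknown or untested is made for them only; others in the source may bear on it.

Measured so far:
compound 1 `CCCCS(=O)(=O)Oc1ccc(/C=C/C(=O)Nc2ccc(C)cc2)cc1OC` – 26800 nM
compound 2 `COc1cc(/C=C/C(=O)Nc2cccc(C)c2)ccc1OS(=O)(=O)c1ccc(Cl)cc1` – 73500 nM

Of the compounds shown here, two have been tested in a toxicity assay on L02 cells (Homo sapiens) for cytotoxicity, read by MTT assay, with a stated time of 24 h; a higher number here means that more compound is tolerated, a lower number that less compound is tolerated. Compound 1 `CCCCS(=O)(=O)Oc1ccc(/C=C/C(=O)Nc2ccc(C)cc2)cc1OC` gives 26800 nM, the lower of the two numbers. Compound 2 `COc1cc(/C=C/C(=O)Nc2cccc(C)c2)ccc1OS(=O)(=O)c1ccc(Cl)cc1` gives 73500 nM, which lies beyond the scatter from the number for compound 1; the two compounds differ in more than one place, so no single change can be read out of that gap.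

Compound 3 `CCCCS(=O)(=O)Oc1ccc(/C=C/C(=O)Nc2ccccc2Br)cc1OC` has not yet been measured in this assay. It differs from compound 1 in one place: 2-bromophenyl in place of 4-methylphenyl on an amide-type nitrogen. Among the measured compounds shown here, no measured pair in this set isolates that change, so nothing in the data shows how this assay responds to it. The step from compound 1 to compound 3 is therefore expected to be small, with no clear direction, and is likely to stay within the scatter of repeated measurements: a 1.1-fold higher number from compound 1 to compound 3 (0.05 log units; within the scatter). Compound 3 is estimated to give 30000 nM in this assay, within a range of 12000 nM to 75000 nM.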

Compound 3, half-maximal cytotoxic concentration: 5000 nM
The estimate for compound 3 lay 6.0-fold (0.78 log units) above the measured number; measured number outside the range, below it.
By their numbers in this assay, from the lowest: compound 3; then compound 1; then compound 2.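

In this assay the substituent on the aryl group at the amide-type nitrogen turns out to matter, since 2-bromophenyl in place of 4-methylphenyl gives a 5.4-fold lower number from compound 1 to compound 3 (0.73 log units; beyond the scatter), a step beyond the scatter that neither earlier compound could isolate. The change leaves the heavy-atom count of the group as it was and adds no hydrogen-bond donors or acceptors, yet less compound is tolerated after it, so those counts alone do not settle the number at this position. Nothing available gives a reason for this step.

The single pair also changes two things at once, the halogen for the methyl and where the group stands on the ring, so the compounds shown cannot tell whether 4-bromophenyl or 2-methylphenyl would follow compound 3 or stay close to compound 1. They also leave open how this assay would respond to an unsubstituted phenyl, to a 2-chlorophenyl, or to a ring carrying an amine or a carboxylic acid at this position, and whether the same swap would act alike on the core of compound 2.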